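The source may report more compounds than this note shows. Statements on the series, on what has been measured and on what is new or still open speak of the compounds shown alone.

Measured so far:
Compound 1, `CCCCN(CCC)c1cc(C)nc2c(-c3ncc(C(F)(F)F)cc3Cl)c(C)nn12`: 1.2 nM
Compound 2, `CCCN(CCC)c1cc(C)nc2c(-c3ncc(C)cc3[N+](=O)[O-])c(C)nn12`: 14 nM
Compound 3, `CCCN(CCC)c1cc(C)nc2c(-c3ncc(N=O)cc3C)c(C)nn12`: 100 nM

All three were tested in an assay on isolated protein for binding affinity to corticotropin-releasing factor receptor 1 (Homo sapiens); on this read-out higher numbers stand for weaker inhibition and lower numbers for stronger inhibition. Among these three numbers, compound 2 holds the second highest; compound 1 gives a lower number and compound 3 a higher one, and both of those gaps lie beyond the usual scatter of repeated measurements, so compound 2 sits clearly between them on this read-out.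

The compound now in question is compound 4, `CCCN(CCC)c1cc(C)nc2c(-c3ncc(C)cc3N)c(C)nn12`. It shares its whole skeleton with compound 2 and differs in a single place: amino in place of nitro on an aromatic carbon. Within the data shown here, no pair among the measured compounds shows this same exchange, so there is no measured step to lean on; the expectation below rests on compound 2 alone and on the nature of the change.

Among the measured compounds shown here, compound 2 is the only measured compound carrying a nitro group, and its value of 14 nM is the anchor. Replacing that nitro with an amino is expected to raise the number in this assay by a moderate step, a 3.6-fold higher number from compound 2 to compound 4 (0.55 log units; beyond the scatter), which would be beyond the scatter. Compound 4 is therefore estimated at 50 nM, with a plausible range from 12 nM to 250 nM.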

Compound 4, inhibition constant: 40 nM
The estimate for compound 4 lay 1.3-fold (0.10 log units) above the measured number, within the range that was stated.
By their numbers in this assay, from the lowest: compound 1; then compound 2; then compound 4; then compound 3.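

Among these compounds, exchanging nitro for amino on this aromatic carbon, ortho to a large group, gives the first measured step at this place: in this assay the change produces a modest shift (a 2.9-fold higher number from compound 2 to compound 4 (0.46 log units; beyond the scatter)). Even with the smaller amino group, which adds a hydrogen-bond donor where the nitro group had none, compound 4 stays on the same nanomolar scale as compound 2, so this place accepts two quite different groups without a collapse in the number. The second step (a 2.5-fold lower number from compound 3 to compound 4 (0.40 log units; beyond the scatter)) exchanges the whole substituted aromatic group on the shared core, a group of 9 heavy atoms giving way to one of 8, so it cannot be pinned on any single atom, and nothing available here speaks to what lies behind either step.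

As far as these compounds go, with everything else held fixed, only nitro and amino can be compared at this carbon, so how a nitrile, a methoxy group or an acetamide would read there remains open. From the compounds shown here alone, it is also open whether the same exchange would give a step of similar size on a compound with the longer butyl chain that compound 1 carries on its amine.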